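Sulfo for Carboxy on a Fused Aromatic Acid

A few compounds are considered here, and "the series" means these few. Any claim that something is new, unique, unknown or untested is made for them only; others in the source may bear on it.

Of the compounds shown here, two sharing one core have been measured in a functional assay on thoracic aorta for antagonist activity at thromboxane A2 receptor (Rattus norvegicus); on this read-out higher numbers stand for weaker inhibition and lower numbers for stronger inhibition. Compound 1 `CC(C)c1ccc2c(CCC/C=N/NC(=O)Nc3ccc(Cl)cc3)cc(C(=O)O)c-2cc1` gives > 100000 nM; this is a limit of the assay rather than a number, and among the values shown it is the limit of > 100000 nM in this assay, at which 1 of the 2 values shown sits. Among the measured compounds shown here, compound 2 `CC(C)c1ccc2c(CCCS(=O)(=O)Nc3ccccc3)cc(C(=O)O)c-2cc1` gives 12000 nM in this assay, the only number recorded, so it stands alone with nothing measured to rank it against. Compound 3 `CC(C)c1ccc2c(CCCS(=O)(=O)Nc3ccccc3)cc(S(=O)(=O)O)c-2cc1` has not yet been measured; it differs from compound 2 by sulfo in place of carboxy on an aromatic carbon. For the measured compounds named here, no step between measured compounds carries this change, so the size of its effect in this assay cannot be read from the data. The expected step from compound 2 to compound 3, a 1.7-fold higher number from compound 2 to compound 3 (0.22 log units; within the scatter), is a modest weakening, possibly not beyond the usual scatter. Compound 3 is therefore expected to give about 20000 nM in this assay, with a plausible range from 5000 nM to 100000 nM.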

Compound 3, half-maximal inhibitory concentration: 8700 nM
Estimate against measurement, compound 3: 2.3-fold (0.36 log units) above; the range from low to high includes it.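

In this assay, the exchange of carboxy for sulfo on an aromatic carbon of the five-membered aromatic ring of carbon only gives the first step read at this position: a 1.4-fold lower number from compound 2 to compound 3 (0.14 log units; within the scatter). On this read-out, compound 2 and compound 3 cannot be told apart, so for this one pair, with the phenyl sulfonamide chain held constant, the position accepts sulfo in place of carboxy without a change that can be distinguished from the scatter. Nothing measured here gives a property of either group that bears on this result, so the pair offers no explanation of it.

What the compounds shown leave open is whether this position needs either group at all, since a hydrogen, a tetrazole or a primary amide on the same aromatic carbon would each show whether the read-out responds to what sits there. Going by these compounds, it also remains open whether sulfo in place of carboxy would behave the same way with the chain of compound 1, whose entry is a limit of the assay and not a number.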